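Nitrophenyl isomers in the series: moving the nitro group

The compounds below may be only part of what the source reports. "The series", "measured", "known", "first", "only" and "open" are said of these compounds alone.

Measured compounds:
compound 1 `CNC(=O)c1cc(Oc2ccc(C3=NNC(c4ccc(Cl)cc4Cl)C3)cc2)ccn1`: "not determined" (no result reported)
compound 2 `CNC(=O)c1cc(Oc2ccc(C3=NNC(c4cccc(Br)c4)C3)cc2)ccn1`: 1960 nM
compound 3 `CNC(=O)c1cc(Oc2ccc(C3=NNC(c4ccc([N+](=O)[O-])cc4)C3)cc2)ccn1`: "not determined" (no result reported)

Compound 3 stands at "not determined" (no result reported) in a functional assay on MCF7 cells (Homo sapiens) for cytotoxicity, read by MTT assay, with a stated time of 72 h (a higher number here means a weaker inhibitor, a lower number a stronger inhibitor), and so offers no number to step from. Compound 4 `CNC(=O)c1cc(Oc2ccc(C3=NNC(c4cccc([N+](=O)[O-])c4)C3)cc2)ccn1` comes next. The change is 3-nitrophenyl in place of 4-nitrophenyl on a saturated ring carbon with 3-nitrophenyl in place of 4-nitrophenyl on a saturated ring carbon. For the measured compounds named here, no measured pair shows the size of such a change in this assay and no direction can be argued from the data. Going by the values given here, a step beyond the scatter is not expected, and the only numerical anchor is compound 2 at 1960 nM in this series. The estimate for compound 4 is an expected 2000 nM within a range of 600 nM to 7000 nM in this read-out.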

Compound 4, half-maximal inhibitory concentration: 35400 nM
Compound 4: middle estimate off by 18-fold (1.25 log units), on the low side; measured number above the stated range.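

In this assay, nitro in place of bromo on an aromatic carbon gives an 18-fold higher number from compound 2 to compound 4 (1.26 log units; beyond the scatter), the first measured size of a change on this aryl group, and the step is large. The move from 4-nitrophenyl to 3-nitrophenyl cannot be read, as compound 3 stands at "not determined" (no result reported). No measurement at hand accounts for the step.

From the compounds shown here alone, whether the nitro position matters at all remains open. Also open, going by these compounds, is whether an amine or a carboxylic acid in place of the nitro group would give a number nearer that of compound 2 or that of compound 4.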